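Dropping the ethyl from the ring alcohol of compound 1

The source may report more compounds than this note shows. Statements on the series, on what has been measured and on what is new or still open speak of the compounds shown alone.

Of the compounds shown here, three sharing one core have been tested in an assay on cells for inhibition of sodium/hydrogen exchanger (Oryctolagus cuniculus); on this read-out lower numbers stand for stronger inhibition and higher numbers for weaker inhibition. Compound 1 `CCC1(O)CS(=O)(=O)c2cc(C(=O)N=C(N)N)c(C)cc21` gives 34 nM. Compound 3 `CO/N=C1\CS(=O)(=O)c2cc(C(=O)N=C(N)N)c(C)cc21` gives 45 nM, a number that sits within the scatter of compound 1. Compound 2 `C=C1c2cc(C)c(C(=O)N=C(N)N)cc2S(=O)(=O)C1(C)C` gives 13 nM, a lower number than compound 1 by more than the scatter, so it stands apart. Compound 4 `Cc1cc2c(cc1C(=O)N=C(N)N)S(=O)(=O)CC2O` differs from compound 1 only in hydrogen in place of ethyl on a saturated ring carbon. Going by the values given here, no measured pair shows this kind of change, so its effect is unknown. With nothing to lean on, the step from compound 1 is expected to be small, a 1.5-fold higher number from compound 1 to compound 4 (0.17 log units; within the scatter), at most modest loss. Compound 4 is therefore estimated at 50 nM, with a range from 15 nM to 160 nM.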

Compound 4, half-maximal inhibitory concentration: 70 nM
Compound 4: the middle estimate sits 1.4-fold (0.15 log units) below what was measured; low and high end bracket the measured number.
By their numbers in this assay, from the lowest: compound 2; then compounds 1, 3 and 4 (each within the scatter of the next, the first and the last beyond it).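

Hydrogen in place of ethyl on this saturated ring carbon gives a 2.1-fold higher number from compound 1 to compound 4 (0.31 log units; beyond the scatter), so this position does respond to the change, though only modestly. Inhibition survives without the ethyl, which means that group is not essential, even if this pair favours keeping it. Nothing measured here explains the shift. A single pair cannot show how the number follows chain length, so a methyl or a propyl on the same carbon remains an open case. Going by these compounds, what an amine would do in place of the ring alcohol also remains open.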